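Chloro for fluoro on the benzyl ring of the amide series

The compounds below may be only part of what the source reports. "The series", "measured", "known", "first", "only" and "open" are said of these compounds alone.

The series rests on a shared core, seen in compound 1 `CC(C)(C)c1cc(CCC(=O)NCCC2CCN(Cc3ccccc3)CC2)cc(C(C)(C)C)c1O` and compound 2 `CC(C)(C)c1cc(/C=C/C(=O)NCCC2CCN(Cc3ccccc3F)CC2)cc(C(C)(C)C)c1O`. In an assay on isolated protein for inhibition of Amine oxidase [flavin-containing] A (Homo sapiens), read by fluorescence, with stated times of 15 min and 20 min (a higher number here means a weaker inhibitor, a lower number a stronger inhibitor), compound 1 gives 94100 nM. In this assay compound 2 gives 60200 nM; its number is the lower of the two, but the gap to compound 1 lies within the scatter, so no order between the two can be read from these data.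

The next compound, compound 3 `CC(C)(C)c1cc(/C=C/C(=O)NCCC2CCN(Cc3ccccc3Cl)CC2)cc(C(C)(C)C)c1O`, differs from compound 2 only by the change (chloro in place of fluoro on an aromatic carbon), chloro in place of fluoro on an aromatic carbon. Among the measured compounds shown here, no measured pair carries this change, so nothing in the numbers speaks to its size or direction. The expectation is that the step from compound 2 to compound 3 stays within the usual scatter, a 1.2-fold lower number from compound 2 to compound 3 (0.08 log units; within the scatter), with no movement beyond it. Compound 3 is estimated at 50000 nM in this assay, expected to fall between 20000 nM and 120000 nM.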

Compound 3, half-maximal inhibitory concentration: 72100 nM
For compound 3 the middle estimate is 1.4-fold (0.16 log units) below the measured one; the measured number falls inside the stated range.
By their numbers in this assay, from the lowest: compounds 2, 3 and 1 (each within the scatter of the next).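

In this assay, among the compounds shown here, the exchange of 2-fluorobenzyl for 2-chlorobenzyl gives a 1.2-fold higher number from compound 2 to compound 3 (0.08 log units; within the scatter) and provides the first reading of a single change. At this position, on an aromatic carbon ortho to a large group, fluoro and chloro cannot be told apart in this assay. Nothing available bears on why the exchange leaves the readings within the scatter.

Still open, as far as these compounds go, is whether a different group at this place, such as methoxy, an amine or a carboxylic acid, would separate from these two halogens, or whether the plain benzyl group on the core of compound 2 would do so. Compound 1 differs from compound 2 in two places, so the separate contributions of the linking chain and the ring substituent remain unresolved.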